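From Trifluoromethyl to Fluoro on the Anilide Ring

A few compounds are considered here, and "the series" means these few. Any claim that something is new, unique, unknown or untested is made for them only; others in the source may bear on it.

Compound 2 `CN(C)C(=O)c1cc2cnc(Nc3ccc(NC(=O)C4(C(=O)Nc5cccc(C(F)(F)F)c5)CC4)cc3)nc2n1C1CCCC1` is the weakest of three measured compounds in a functional assay on T47D cells (Homo sapiens) for inhibition, read by CCK-8 assay, with a stated time of 72 h, tested at 1 uM (a higher number here means more inhibition of growth at the concentration tested, a lower number less inhibition of growth), giving 9.7%. Compound 1 `CN(C)C(=O)c1cc2cnc(Nc3ccc(NC(=O)C4(C(=O)Nc5ccccc5)CC4)cc3)nc2n1C1CCCC1`, which carries hydrogen at the same place, gives 52.8%, and compound 3 `CN(C)C(=O)c1cc2cnc(Nc3ccc(NC(=O)C4(C(=O)Nc5cccc(Cl)c5)CC4)cc3)nc2n1C1CCCC1`, with chloro there, gives 39.3%. Compound 4 `CN(C)C(=O)c1cc2cnc(Nc3ccc(NC(=O)C4(C(=O)Nc5cccc(F)c5)CC4)cc3)nc2n1C1CCCC1` differs from compound 2 in one place: fluoro in place of trifluoromethyl on an aromatic carbon. Among the compounds with values here, two measured steps bear on this change. Growth inhibition fell a number 43.1 percentage points lower from compound 1 to compound 2 (beyond the scatter), and it rose a number 29.6 percentage points higher from compound 2 to compound 3 (beyond the scatter), so a smaller group on this ring carbon went with more inhibition in both cases. Fluoro is smaller than chloro, so a rise of about a number 35.3 percentage points higher from compound 2 to compound 4 (beyond the scatter) is expected, and compound 4 is estimated at 45%, between 30% and 60%.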

Compound 4, percent growth inhibition at one concentration: -3.2%
For compound 4 the middle estimate is 48.2 percentage points above the measured one; the whole stated range lies above it.
By their numbers in this assay, from the lowest: compound 4; then compound 2; then compound 3; then compound 1.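

Fluoro in place of trifluoromethyl gave a number 12.9 percentage points lower from compound 2 to compound 4 (beyond the scatter), while fluoro gave a number 42.5 percentage points lower from compound 3 to compound 4 (beyond the scatter) against chloro and a number 56 percentage points lower from compound 1 to compound 4 (beyond the scatter) against hydrogen. The link between a smaller group and more inhibition, suggested by compound 1, compound 2 and compound 3, therefore breaks at compound 4, so group size alone does not order this ring carbon. Nothing available here explains this reversal. Going by these compounds, how a methoxy group, an amine or a carboxylic acid would behave on this same carbon remains open.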